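Aryl swap on the ring amine nitrogen of compound 2

The compounds below may be only part of what the source reports. "The series", "measured", "known", "first", "only" and "open" are said of these compounds alone.

For the measured compounds named here, compound 2 `CCCc1cnc2c(C#N)c(N3CCN(c4nc(C)cc(C)n4)CC3)ccn12` is the only member of the series with a number in a functional assay on CHO cells with metabotropic glutamate receptor 2 (Homo sapiens) as the target, read by GTPgammaS binding; on this read-out higher numbers stand for an effect only at larger amounts of compound and lower numbers for an effect already at smaller amounts: compound 2 gives 646 nM. Compound 1 `CCCc1cnc2c(C#N)c(N3CCN(c4ncccn4)CC3)ccn12` reaches only a limit in this assay, > 3160 nM (the limit of > 3160 nM in this assay, at which 1 of the 2 values shown sits). Going by the values given here, the one measured step, an at least 4.8-fold lower number from compound 1 to compound 2 (0.68 log units; beyond the scatter), is therefore known only as a lower bound on its size.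

Compound 3 `CCCc1cnc2c(C#N)c(N3CCN(c4ccccc4)CC3)ccn12` differs from compound 2 by phenyl in place of 4,6-dimethylpyrimidin-2-yl on an amine nitrogen in a ring. Among the compounds with values here, no measured step covers this change directly: the step from compound 1 to compound 2 adds methyl groups to the six-membered aromatic ring with 2 hetero atoms and keeps the ring nitrogens, whereas the change to compound 3 removes the methyl groups and the ring nitrogens together. The only pointer available is that the unmethylated ring of compound 1 sits at the limit; whether a carbon-only ring behaves like compound 1 or like compound 2 cannot be read from these two values. The expected step is a 2.3-fold higher number from compound 2 to compound 3 (0.37 log units; beyond the scatter), toward a larger number with a wide range. Compound 3 is estimated at 1500 nM, between 300 nM and 8000 nM, with a real chance that this assay again reports only a limit.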

Compound 3, half-maximal effective concentration: 977 nM
The estimate for compound 3 lay 1.5-fold (0.19 log units) above the measured number; measured number inside the range.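

In this assay, the ring nitrogens and methyl groups of 4,6-dimethylpyrimidin-2-yl can give way together to phenyl on the amine nitrogen in the ring without a change that exceeds the scatter, as shown by a 1.5-fold higher number from compound 2 to compound 3 (0.18 log units; within the scatter). On these data alone, this position therefore accepts a six-membered aromatic ring of carbon only, and compounds 2 and 3 cannot be told apart on this read-out, while phenyl in place of the unmethylated ring gives an at least 3.2-fold lower number from compound 1 to compound 3 (0.50 log units; beyond the scatter), a step whose true size remains unknown beyond this lower bound. Among the three compounds, the unmethylated pyrimidin-2-yl of compound 1 is the only one without a number, and its value is a limit: the limit of > 3160 nM in this assay, at which 1 of the 3 values shown sits.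

The separate contributions of the ring nitrogens and the methyl groups remain unresolved, since compound 3 loses both at once, and 3,5-dimethylphenyl or 4,6-dimethylpyridin-2-yl would be needed to pull them apart. Also open, as far as these compounds go, is whether a group with a different ring, such as pyridin-2-yl, follows compounds 2 and 3 or stays at a limit like compound 1.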